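Benzothiazole-free wording: an aniline replaces a urea

This account rests on a few compounds, and the source may have more. Where it says the series, first, only, none or still open, it means among the compounds named here.

Compound 1 `CC(C)COC(=O)Nc1nc2ccc(NC(=O)c3c(Cl)cccc3Cl)cc2s1`: 0.0035 ug/mL
Compound 2 `CCCCNC(=O)Nc1nc2ccc(NC(=O)c3c(Cl)cccc3Cl)cc2s1`: 0.028 ug/mL

In a functional assay on WI-38 VA13 cells (Homo sapiens) for cytotoxicity (a lower number here means that less compound is needed, a higher number that more compound is needed for the effect), compound 2 gives the higher of the two numbers; compound 1 gives the lower one, and the step of an 8.0-fold higher number from compound 1 to compound 2 (0.90 log units; beyond the scatter) lies beyond the scatter. Compound 3 `COc1ccccc1Nc1nc2ccc(NC(=O)c3c(Cl)cccc3Cl)cc2s1` differs from compound 2 by 2-methoxyphenyl in place of butylcarbamoyl on a nitrogen on an aromatic ring. Among the measured compounds shown here, no measured step covers this kind of change; the one step known shows only that changing the group on that nitrogen alters the number. Compound 3 is therefore expected at 0.05 ug/mL, within 0.01 ug/mL to 0.3 ug/mL, an estimated step of a 1.8-fold higher number from compound 2 to compound 3 (0.25 log units; within the scatter).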

Compound 3, half-maximal effective concentration: > 7.2 ug/mL
Compound 3 ended at the assay's limit; the forecaster's own chance of this, stated with the estimate: 5%; at least 140-fold (2.15 log units) between middle value and limit.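

In this assay, the group on this nitrogen on an aromatic ring can shift the number far more than the first pair showed: 2-methoxyphenyl gives an at least 250-fold higher number from compound 2 to compound 3 (2.41 log units; beyond the scatter) and an at least 2000-fold higher number from compound 1 to compound 3 (3.31 log units; beyond the scatter). Both groups that place a carbonyl on this nitrogen, isobutoxycarbonyl and butylcarbamoyl, give far lower numbers than 2-methoxyphenyl. Compound 3 gives a limit of the assay, not a number: the limit of > 7.2 ug/mL in this assay, at which 1 of the 3 values shown sits.

On these data alone, it remains open whether the loss of the carbonyl or the arrival of the aromatic ring drives this step. A butyl chain or an acetyl group on that nitrogen would help separate the two.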